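The compounds below may be only part of what the source reports. "The series", "measured", "known", "first", "only" and "open" are said of these compounds alone.

Working notes on the series.

Among the measured compounds shown here, compound 1 `CC(Sc1nc2c(cnn2C)c(=O)n1-c1ccccc1)c1ccccn1` carries the lowest number of the three measured so far: in an assay on isolated protein for inhibition of retinal dehydrogenase 2 (Homo sapiens) (a lower number here means a stronger inhibitor, a higher number a weaker inhibitor), compound 1 gives 63 nM. Compound 2 `CC(Sc1nc2nn(C3COC3)cc2c(=O)n1-c1ccccc1)c1ccccc1` sits alongside it, and in this assay compound 2 gives 65 nM, a value within the scatter of that for compound 1, so no order between the two can be read. Compound 3 `Cn1ncc2c(=O)n(-c3ccccc3)c(/C=C/c3cccc(F)c3)nc21` is the outlier: in this assay compound 3 gives 440 nM, a number beyond the scatter relative to compound 1. For the measured compounds named here, no single-point steps between measured compounds are available.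

Compound 4 `Cn1ncc2c(=O)n(-c3ccccc3)c(SC(C)(C)c3ccccc3)nc21` is not yet measured. It differs from compound 1 as follows: 1-methyl-1-phenylethyl in place of 1-(pyridin-2-yl)ethyl on a sulfur. The nearest guide is compound 2, whose sulfur-linked group also carries a phenyl and whose value of 65 nM matches that of compound 1, which suggests the shared core tolerates such groups on the sulfur. From the compounds shown here alone, the extra methyl and the loss of the acceptor are untested in this set. For compound 4 the expected step of a 1.4-fold higher number from compound 1 to compound 4 (0.15 log units; within the scatter) is small, toward a slightly higher number, and likely within or only just beyond the scatter. Compound 4 is therefore estimated at 90 nM, with a range from 30 nM to 300 nM.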

Compound 4, half-maximal inhibitory concentration: 2200 nM
Compound 4: middle estimate off by 24-fold (1.39 log units), on the low side; measured number outside the range, above it.
By their numbers in this assay, from the lowest: compounds 1 and 2 (each within the scatter of the next); then compound 3; then compound 4.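

In this assay, among the compounds shown here, the group on the sulfur proves far more decisive than the earlier compounds could show: 1-methyl-1-phenylethyl in place of 1-(pyridin-2-yl)ethyl gives a 35-fold higher number from compound 1 to compound 4 (1.54 log units; beyond the scatter), with the rest of the molecule unchanged. This single step replaces a ring containing a hetero atom with a ring of carbon only and also changes the substitution of the group, so it shows that this position is sensitive but does not separate the two differences. No measurement at hand accounts for the rise.

Which difference carries the step stays open: 1-methyl-1-(pyridin-2-yl)ethyl on the sulfur of the same core would keep the ring of compound 1 and change only the substitution. From the compounds shown here alone, whether 1-phenylethyl on that core stays close to compound 1 is equally open.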